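This account rests on a few compounds, and the source may have more. Where it says the series, first, only, none or still open, it means among the compounds named here.

Measured so far in a functional assay (a higher number here means a weaker inhibitor, a lower number a stronger inhibitor), are two compounds:

Compound 1 `CC(C)=CCOc1cc(O)c2c(c1)OC(c1cccc(Br)c1)CC2=O` with 4040 nM
Compound 2 `COc1ccc(C2CC(=O)c3c(O)cc(OCC=C(C)C)cc3O2)cc1` with 5080 nM

With only these two numbers available, compound 2 at 5080 nM lies within the scatter of compound 1 and cannot be ranked against it. Compound 3 `CC(C)=CCOc1cc(O)c2c(c1)OC(c1ccc(C)cc1C)CC2=O` has not yet been measured. It carries 2,4-dimethylphenyl in place of 4-methoxyphenyl on a saturated ring carbon, next to the ring oxygen, and the counted difference is 2,4-dimethylphenyl in place of 4-methoxyphenyl on a saturated ring carbon at this position. Within the data shown here, since the only measured change on this carbon is a 1.3-fold higher number from compound 1 to compound 2 (0.10 log units; within the scatter) and no other step bears on the question, no step beyond the scatter is expected in this assay for compound 3. Among the measured compounds shown here, this evidence is thin, as no measured compound carries a dimethylphenyl group. The expected step is a 1.1-fold lower number from compound 2 to compound 3 (0.05 log units; within the scatter) by this estimate. For compound 3 the estimated value is 4500 nM with an expected range of 1500 nM to 13000 nM around it.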

Compound 3, half-maximal inhibitory concentration: 6380 nM
Compound 3: the middle estimate sits 1.4-fold (0.15 log units) below what was measured; the measured number falls inside the stated range.
By their numbers in this assay, from the lowest: compounds 1, 2 and 3 (each within the scatter of the next).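

In this assay, putting 2,4-dimethylphenyl in place of 4-methoxyphenyl on the saturated ring carbon next to the ring oxygen gives a 1.3-fold higher number from compound 2 to compound 3 (0.10 log units; within the scatter), and putting it in place of 3-bromophenyl on the same carbon gives a 1.6-fold higher number from compound 1 to compound 3 (0.20 log units; within the scatter). This carbon has now carried three differently substituted phenyl groups, and neither new step leaves the scatter, even though the hydrogen-bond acceptor counted on 4-methoxyphenyl is absent from 2,4-dimethylphenyl, which has only carbon atoms. No independent measurement bears on this result, so the reading rests on these numbers alone.

The compounds shown leave open whether a phenyl group is needed on this carbon at all, and whether a group of another kind, such as a pyridine ring or a simple methyl group, would give a step beyond the scatter. All three also share the rest of the core, so they say nothing about changes elsewhere or about what a carboxylic acid or an amine on the phenyl ring would do.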